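A few compounds are considered here, and "the series" means these few. Any claim that something is new, unique, unknown or untested is made for them only; others in the source may bear on it.

Compound 1, `CC(C)N(Cc1cccc(OCCCCCC(=O)O)c1)C(=O)c1ccc(-c2ccoc2)cc1`: in an ADME assay on BJ cells (Homo sapiens) for cytotoxicity, read by CellTiter-Glo and resazurin assay, with a stated time of 72 h (a higher number here means that more compound is needed for the effect, a lower number that less compound is needed), compound 1 gives > 26000 nM, which is a limit of the assay rather than a number.
Compound 2, `CC(C)N(Cc1cccc(OCCCCCC(=O)O)c1)C(=O)c1ccc(-c2cc3ccccc3n2S(=O)(=O)c2ccccc2)cc1`: in this assay compound 2 gives > 26000 nM, likewise a limit of the assay.

Compound 2 therefore stands at the edge of what the assay can report, and so does compound 1, as the limit of > 26000 nM in this assay, at which 2 of the 2 values shown sit, shows: neither compound reaches a measurable effect within the tested range. Within the data shown here, no step between two measured compounds that differ in a single place is recorded here, so no measured guide exists for the size of any change.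

Compound 3, `CCOC(=O)CCCCCOc1cccc(CN(C(=O)c2ccc(-c3cc4ccccc4n3S(=O)(=O)c3ccccc3)cc2)C(C)C)c1`, differs from compound 2 by ethyl in place of hydrogen on an oxygen next to a carbonyl group. With both measured values sitting at the same limit, there is no basis to expect a shift in either direction, and none beyond the usual scatter is anticipated. The step that the limit leaves unreadable from compound 2 to compound 3 is expected to be essentially nil. Compound 3 is thus estimated at 30000 nM, in a range from 13000 nM to 70000 nM, and most likely the assay will again report only a limit.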

Compound 3, half-maximal effective concentration: > 26000 nM
Compound 3 ended at the assay's limit; the forecaster's own chance of this, stated with the estimate: 80%; the middle value lies beyond the limit too.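

No size can be read for the change from compound 2 to compound 3, because both results are limits of the assay, not numbers: the limit of > 26000 nM in this assay, at which 3 of the 3 values shown sit.

Still open, on these data alone, is whether ethyl in place of hydrogen on an oxygen next to a carbonyl group changes the concentration needed for an effect in this assay, and how much compound that would take.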